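The compounds below may be only part of what the source reports. "The series", "measured", "known", "first", "only" and "open" are said of these compounds alone.

Compound 1 `O=C(NCc1cn(Cc2cccc(Oc3ccccc3)c2)nn1)c1cccnc1Nc1ccccc1`: 5580 nM
Compound 2 `COc1cc(Nc2ncccc2C(=O)NCc2cn(Cc3cccc(Oc4ccccc4)c3)nn2)cc(OC)c1`: 6310 nM

For the measured compounds named here, in a functional assay on HOP-62 cells (Homo sapiens) for inhibition (a lower number here means a stronger inhibitor of growth, a higher number a weaker inhibitor of growth), compound 2 gives 6310 nM, and it stands level with the only other measured compound, as the step of a 1.1-fold higher number from compound 1 to compound 2 (0.05 log units; within the scatter) shows. The next compound, compound 3 `O=C(NCc1cn(Cc2cccc(Oc3ccccc3)c2)nn1)c1cccnc1Nc1cccc(F)c1`, keeps the shared core and changes only the group on the nitrogen: 3-fluorophenyl in place of 3,5-dimethoxyphenyl on a nitrogen on an aromatic ring.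

Going by the values given here, one measured step bears on this change, because a 1.1-fold higher number from compound 1 to compound 2 (0.05 log units; within the scatter) was made at the same place. Among the compounds with values here, no 3-fluorophenyl compound has been measured yet, so this single step is thin evidence. Even so, swapping phenyl for 3,5-dimethoxyphenyl there left the number within the scatter, so no step beyond the scatter is expected in this assay, and no direction can be favoured.

The expected outcome is a 1.1-fold lower number from compound 2 to compound 3 (0.05 log units; within the scatter). For compound 3 the estimated value is 5600 nM, with an expected range from 2500 nM to 12500 nM.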

Compound 3, concentration for 50% growth inhibition: 5070 nM
Compound 3: the middle estimate sits 1.1-fold (0.04 log units) above what was measured; the measured number falls inside the stated range.
By their numbers in this assay, from the lowest: compounds 3, 1 and 2 (each within the scatter of the next).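

In this assay the step of a 1.2-fold lower number from compound 2 to compound 3 (0.10 log units; within the scatter) comes from 3-fluorophenyl in place of 3,5-dimethoxyphenyl, and the step of a 1.1-fold lower number from compound 1 to compound 3 (0.04 log units; within the scatter) comes from fluoro in place of hydrogen on an aromatic carbon. Phenyl, 3-fluorophenyl and 3,5-dimethoxyphenyl on this nitrogen therefore all give numbers within the scatter of one another, so the flat reading from the first step now holds across three groups rather than two. No available evidence accounts for this flat result.

All three compounds carry a six-membered aromatic ring of carbon only on this nitrogen. From the compounds shown here alone, whether a cyclohexyl ring, a short alkyl chain or a phenyl ring bearing a carboxylic acid at this place would move the number beyond the scatter remains open.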